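The source may report more compounds than this note shows. Statements on the series, on what has been measured and on what is new or still open speak of the compounds shown alone.

Measured in a functional assay on MDA-MB-231 cells (Homo sapiens) for cytotoxicity, read by MTT assay, with a stated time of 24 h; on this read-out lower numbers stand for stronger inhibition and higher numbers for weaker inhibition:

- Compound 1 `Fc1cc(F)cc(-c2nc3cccnc3n2C2CCCC2)c1`: 138 nM
- Compound 2 `Cc1cccc(-c2nc3cccnc3n2C2CCCC2)c1Cl`: 646 nM
- Compound 3 `c1ccc(Oc2ccc(-c3nc4cccnc4n3C3CCCC3)cc2)cc1`: > 10000 nM (a limit)

Compound 3 gives > 10000 nM, which is a limit of the assay and not a number. Its standing among the three compounds is therefore (the limit of > 10000 nM in this assay, at which 1 of the 3 values shown sits).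

Compound 4 `NC(=O)c1ccc(-c2nc3cccnc3n2C2CCCC2)cc1` keeps the shared core and changes one place on compound 3: carbamoyl in place of phenoxy on an aromatic carbon. The new group stands on the same aromatic carbon, para to a large group.

Among the measured compounds shown here, no step between measured compounds is available to size this change, so the expectation rests on the values alone. Without the phenoxy group, compound 1 gives 138 nM and compound 2 gives 646 nM in this assay. A large step toward stronger inhibition is therefore expected, though its full size cannot be fixed from a limit. The expected change is an at least 8.3-fold lower number from compound 3 to compound 4 (0.92 log units; beyond the scatter). For compound 4 the estimated value is 1200 nM, with an expected range of 200 nM to 8000 nM.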

Compound 4, half-maximal inhibitory concentration: 8000 nM
Compound 4: the middle estimate sits 6.7-fold (0.82 log units) below what was measured, within the range that was stated.
By their numbers in this assay, from the lowest: compound 1; then compound 2; then compound 4. At a limit, above all of these: compound 3.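

In this assay, putting carbamoyl in place of phenoxy on the aromatic carbon para to a large group gives an at least 1.2-fold lower number from compound 3 to compound 4 (0.09 log units; that floor lies within the scatter), so the measured floor of this change does not by itself establish a real gain. Compound 3 stands only at a limit of the assay, not at a number: the limit of > 10000 nM in this assay, at which 1 of the 4 values shown sits. What is new is that this position, with carbamoyl on it, now gives a readable number, as compound 4 gives 8000 nM. The full size of the step cannot be fixed from the limit of compound 3.

The compounds shown leave open how an amine, a carboxylic acid or a nitrile would read on this same aromatic carbon. They also leave open how a small methoxy or a single fluorine would read there.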